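The source may hold more compounds than are shown below. What is called first, only, known or untested is meant among the compounds shown, and "the series" means these compounds.

Of the compounds shown here, two sharing one core have been measured in a physicochemical assay for solubility, using the shake flask method, with a stated time of 12 h; a lower number here means a less soluble compound, a higher number a more soluble compound. Compound 1 (`O=C(/C=C/c1ccc(O)c(O)c1)/C=C/c1ccccc1O`) gives 111000 nM, and compound 2 (`O=C(/C=C/c1cccc(O)c1)/C=C/c1ccc(O)c(O)c1`) gives 60000 nM. For the measured compounds named here, the one measured step between them, a 1.9-fold lower number from compound 1 to compound 2 (0.27 log units; within the scatter), does not separate the pair, so compound 2 stands level with compound 1 on these two numbers.

Compound 3 (`O=C(/C=C/c1ccc(O)cc1)/C=C/c1ccc(O)c(O)c1`) differs from compound 2 in one place, 4-hydroxyphenyl in place of 3-hydroxyphenyl on a double-bonded chain carbon bound to a double-bonded chain carbon. Going by the values given here, the only measured guide is the step at that same place, where compound 2 carries 3-hydroxyphenyl in place of the 2-hydroxyphenyl of compound 1, and that step was a 1.9-fold lower number from compound 1 to compound 2 (0.27 log units; within the scatter). Among the compounds with values here, no compound with 4-hydroxyphenyl at this place has yet been measured, so this single small step is thin evidence. Even so, no change beyond the scatter is expected in this assay. The expected step is a 1.1-fold higher number from compound 2 to compound 3 (0.03 log units; within the scatter). For compound 3 the estimated value is 65000 nM, with an expected range from 28000 nM to 140000 nM.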

Compound 3, solubility: 19000 nM
Estimate against measurement, compound 3: 3.4-fold (0.53 log units) above; measured number outside the range, below it.
By their numbers in this assay, from the lowest: compound 3; then compounds 2 and 1 (each within the scatter of the next).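

At this place, on a double-bonded chain carbon bound to a double-bonded chain carbon, the choice among the hydroxyphenyl groups now shows up in this assay: 4-hydroxyphenyl in place of 3-hydroxyphenyl gives a 3.2-fold lower number from compound 2 to compound 3 (0.50 log units; beyond the scatter), and 4-hydroxyphenyl in place of 2-hydroxyphenyl gives a 5.8-fold lower number from compound 1 to compound 3 (0.77 log units; beyond the scatter). For the compounds shown here, the earlier step did not separate 2-hydroxyphenyl from 3-hydroxyphenyl, so 4-hydroxyphenyl is the first group here to stand apart, with compound 3 lowest of the three, even though the groups that leave and enter have the same atoms and the same counts of donors and acceptors. No measurement is available that bears on what lies behind this difference.

The compounds shown leave open whether a methoxy group or an amine on the phenyl ring at this place, in place of the hydroxyl, would give a number closer to compound 3 or to compound 2. As far as these compounds go, the rest of the shared core is the same in all three compounds, so it is also open whether the step to 4-hydroxyphenyl would keep its size with another group, such as a carboxylic acid, elsewhere on that core.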